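The compounds below may be only part of what the source reports. "The series", "measured", "known", "first", "only" and "open" are said of these compounds alone.

Measured so far:
compound 1 `CC(C)CCC(=O)N[C@@H](C(=O)N1CCC(c2ccc(Cl)cc2)CC1)C(C)C`, 26 nM;
compound 2 `CC(C)C(NC(=O)c1ccccc1)C(=O)N1CCC(c2ccc(F)cc2)CC1`, 423 nM;
compound 3 `CC(C)C(NC(=O)c1ccccc1)C(=O)N1CCN(c2ccc(Cl)c(Cl)c2)CC1`, 375 nM.

These numbers come from an assay on THP-1 cells for displacement of a labelled ligand from C-C chemokine receptor type 1 (Homo sapiens); on this read-out higher numbers stand for weaker inhibition and lower numbers for stronger inhibition. On this read-out compound 1 has the lowest number of the three, and both of the others stand well apart from it, beyond the usual scatter, so compound 1 is the strongest inhibitor shown here. Compound 4 `CC(C)[C@@H](NC(=O)CC1CC1)C(=O)N1CCC(c2ccc(Cl)cc2)CC1` has not yet been measured. It differs from compound 1 in one place: cyclopropyl in place of isobutyl on a saturated chain carbon bound to a carbonyl carbon. Within the data shown here, no measured pair shows this change, so its effect is unknown; a modest weakening is expected, with the estimated step of a 2.1-fold higher number from compound 1 to compound 4 (0.33 log units; beyond the scatter) from compound 1 to compound 4. Compound 4 is thus expected to give about 55 nM, somewhere between 15 nM and 200 nM.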

Compound 4, half-maximal inhibitory concentration: 46 nM
Compound 4: the middle estimate sits 1.2-fold (0.08 log units) above what was measured; measured number inside the range.
By their numbers in this assay, from the lowest: compounds 1 and 4 (each within the scatter of the next); then compounds 3 and 2 (each within the scatter of the next).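

In this assay, cyclopropyl in place of isobutyl on a saturated chain carbon bound to a carbonyl carbon gives a 1.8-fold higher number from compound 1 to compound 4 (0.25 log units; within the scatter). This read-out therefore does not separate compound 1 from compound 4, and this position accepts a three-membered carbon ring as well as the open-chain isobutyl group. Nothing measured here offers an explanation for this result. On these data alone, whether the position also accepts an amine, a carboxylic acid or a longer chain remains open. So does whether this change gives a similar result on any other core.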